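The source may hold more compounds than are shown below. What is called first, only, known or untested is meant among the compounds shown, and "the series" means these compounds.

Compound 2 `CS(=O)(=O)NC[C@H]1CN(c2ccc(-n3cc(-c4ccccn4)cn3)c(F)c2)C(=O)O1` gives only a limit in an ADME assay on L02 cells (Homo sapiens) for cytotoxicity, read by MTT assay, with a stated time of 48 h (on this read-out lower numbers stand for stronger inhibition and higher numbers for weaker inhibition), namely > 400 ug/mL. Compound 1 `O=C1O[C@@H](CN2CCC(O)CC2)CN1c1ccc(-n2cc(-c3ccccn3)cn2)c(F)c1` likewise gives only a limit in this assay, > 400 ug/mL. The change from compound 1 to compound 2 a step that the two limits leave unreadable from compound 1 to compound 2 therefore cannot be read in size, as both sit at the limit of > 400 ug/mL in this assay, at which 2 of the 2 values shown sit. Compound 3 `NC(=O)[C@H]1CN(c2ccc(-n3cc(-c4ccccn4)cn3)c(F)c2)C(=O)O1` differs from compound 2 by carbamoyl in place of (methanesulfonamido)methyl on a saturated ring carbon. With no readable step to lean on, compound 3 is expected to remain at the same limit, so the estimated step of a number no higher from compound 2 to compound 3 (the limit leaves the size open) is none beyond the scatter. Compound 3 is estimated at 400 ug/mL, between 150 ug/mL and 1000 ug/mL.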

Compound 3, half-maximal inhibitory concentration: 119 ug/mL
Estimate against measurement, compound 3: 3.4-fold (0.53 log units) above, and the stated range ends above it.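

In this assay, carbamoyl on the saturated ring carbon next to the ring oxygen brings an at least 3.3-fold lower number from compound 2 to compound 3 (0.52 log units; beyond the scatter), and the same group brings an at least 3.3-fold lower number from compound 1 to compound 3 (0.52 log units; beyond the scatter). This position can therefore move the read-out, which neither side chain of the earlier compounds had shown. Both sizes are only minimum sizes, as compound 1 and compound 2 each give a limit and not a number: the limit of > 400 ug/mL in this assay, at which 2 of the 3 values shown sit.

The compounds shown leave open whether an aminomethyl group or a carboxylic acid on this carbon would stay close to compound 3 or return to the limit.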